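The compounds below may be only part of what the source reports. "The series", "measured", "known", "first", "only" and "open" are said of these compounds alone.

Measured compounds:
compound 1 `Cc1ccc(C(=O)N2N=C(c3ccccc3)CC2c2cn(C)c3ccccc23)cn1`: 1190 nM
compound 2 `Cn1cc(C2CC(c3ccccc3)=NN2C(=O)c2ccncc2)c2ccccc21`: 990 nM

For the measured compounds named here, in a functional assay on A549 cells (Homo sapiens) for inhibition, read by MTT assay, with a stated time of 48 h (a higher number here means a weaker inhibitor of growth, a lower number a stronger inhibitor of growth), compound 1 gives 1190 nM, level with the only other measured number. Compound 3 `COc1cc(C2=NN(C(=O)c3ccc(C)nc3)C(c3cn(C)c4ccccc34)C2)cc(OC)c1OC` differs from it as follows: 3,4,5-trimethoxyphenyl in place of phenyl on a carbon with a double bond to nitrogen. Going by the values given here, the one measured step, a 1.2-fold lower number from compound 1 to compound 2 (0.08 log units; within the scatter), swaps the group on a carbonyl carbon, a different place, so nothing measured tests this change or shows its direction. No step beyond the scatter in this assay is therefore expected, though with wide uncertainty. The expected step is a 1.6-fold lower number from compound 1 to compound 3 (0.20 log units; within the scatter). Compound 3 is estimated at 750 nM, with an expected range of 150 nM to 2500 nM.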

Compound 3, concentration for 50% growth inhibition: 230 nM
Compound 3: the middle estimate sits 3.3-fold (0.51 log units) above what was measured, and the stated range covers the measured number.
By their numbers in this assay, from the lowest: compound 3; then compounds 2 and 1 (each within the scatter of the next).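

In this assay, 3,4,5-trimethoxyphenyl in place of phenyl gives a 5.2-fold lower number from compound 1 to compound 3 (0.71 log units; beyond the scatter), so this position on the shared core, untested by the earlier pair, does respond to a change of group. This is the first step beyond the scatter among these compounds. Nothing here gives a reason for it. 

Whether all three methoxy groups matter stays open, since a phenyl carrying a single methoxy group, a fluorine or an amine is not among the compounds shown. Also open, going by these compounds, is whether the same swap would act alike with the pyridin-4-yl of compound 2.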